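Fluoro-to-chloro step on a second acid core

The source may hold more compounds than are shown below. What is called first, only, known or untested is meant among the compounds shown, and "the series" means these compounds.

Measured so far in a physicochemical assay for lipophilicity; on this read-out higher numbers stand for higher lipophilicity and lower numbers for lower lipophilicity:
compound 1 `O=C(O)CC(CC(=O)NNC(=O)CCCCNc1ccccn1)c1ccc(F)cc1` gives 2.23
compound 2 `O=C(O)CC(CC(=O)NNC(=O)CCCCNc1ccccn1)c1ccc(Cl)cc1` gives 2.63
compound 3 `O=C(O)CC(NC(=O)NNC(=O)CCCCNc1ccccn1)c1ccc(F)cc1` gives 1.8

Compounds 1 and 2 share a core and differ in one place: chloro in place of fluoro on an aromatic carbon. In this assay this gives a number 0.40 log units higher from compound 1 to compound 2 (beyond the scatter), a step beyond the usual scatter.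

Compound 3 carries a different core; how the two cores differ is not broken down here. Compound 3 stands lowest of the three numbers, with compound 1 the nearest and compound 2 the furthest, both gaps beyond the scatter.

Compound 4 `O=C(O)CC(NC(=O)NNC(=O)CCCCNc1ccccn1)c1ccc(Cl)cc1` is not yet measured in this assay. It relates to compound 3 as compound 2 relates to compound 1: chloro in place of fluoro on an aromatic carbon. The place of the change is the same in both pairs, para to a large group on the carbon-only ring, so the same change is made on a second core.

The step is expected to be a number 0.40 log units higher from compound 3 to compound 4 (beyond the scatter), resting on the measured step of a number 0.40 log units higher from compound 1 to compound 2 (beyond the scatter). Compound 4 is therefore estimated at 2.2, with a range from 1.9 to 2.5.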

Compound 4, partition coefficient: 2.2
Compound 4: the middle estimate sits on the measured number at the digits printed, and the stated range covers the measured number.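

In this assay chloro in place of fluoro on an aromatic carbon gives a number 0.40 log units higher from compound 3 to compound 4 (beyond the scatter) on the core of compound 3 and a number 0.40 log units higher from compound 1 to compound 2 (beyond the scatter) on the core of compound 1, so the change carries across these two cores with a step of the same size at the digits printed. Going by these compounds alone, this rests on only two matched pairs and does not show that a step of this size would hold on any further core. No measurement at hand bears on why the step takes this size.

The compounds shown carry only fluoro and chloro on that aromatic carbon, so it remains open how bromo, methyl or methoxy at the same place would read on either core. Also open, from the compounds shown here alone, is whether the step holds on a core with a longer chain, or with an amine in place of the carboxylic acid.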